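Two Amides at the Same Limit

The compounds below may be only part of what the source reports. "The series", "measured", "known", "first", "only" and "open" are said of these compounds alone.

Measured in an ADME assay on BJ cells (Homo sapiens) for inhibition, with a stated time of 72 h; a lower number here means that less compound is needed, a higher number that more compound is needed for the effect:
Compound 1 `C/C=C/C(=O)Nc1cccc(-c2nc3ccccc3s2)c1` gives > 25000 nM, a limit of the assay.
Compound 2 `O=C(Nc1cccc(-c2nc3ccccc3s2)c1)c1cnccc1Cl` gives > 25000 nM, also a limit of the assay.

Within the data shown here, compound 1 therefore stands only at a limit here, and the one other value shown is a limit as well. The step that the two limits leave unreadable from compound 1 to compound 2 cannot be read, because both ends sit at the limit of > 25000 nM in this assay, at which 2 of the 2 values shown sit.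

Compound 3 `O=C(Nc1cccc(-c2nc3ccccc3s2)c1)c1cccnc1Cl` differs from compound 1 by 2-chloropyridin-3-yl in place of prop-1-en-1-yl on a carbonyl carbon. Among the measured compounds shown here, no measured step speaks to this change in size, and the only related step is the unreadable one from compound 1 to compound 2. There is thus no basis for expecting a reading below the limit, and a value of the same kind as for compound 1 is expected. The estimate for compound 3 is 30000 nM, between 10000 nM and 100000 nM, which would mean an expected step that the limit leaves unreadable from compound 1 to compound 3.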

Compound 3, half-maximal effective concentration: > 25000 nM
Compound 3: a limit, no number; the forecaster's own chance of this, stated with the estimate: 80%; the middle value is on the limit's open side.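

In this assay compound 3 gives > 25000 nM, a limit, so neither its step from compound 1 nor its step from compound 2 can be read: the limit of > 25000 nM in this assay, at which 3 of the 3 values shown sit. The compounds shown leave open how compound 1, compound 2 and compound 3 truly compare, and whether any group on this carbonyl carbon gives a reading within the assay's limit.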